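Carbamoyl to methoxymethyl: an expected small shift

This account rests on a few compounds, and the source may have more. Where it says the series, first, only, none or still open, it means among the compounds named here.

Among the compounds with values here, compound 1 `Cn1ncc(Cl)c1-c1cc(C(=O)N[C@@H]2CN[C@H](CC(N)=O)C[C@H]2c2ccc(Cl)c(Cl)c2)oc1Cl` holds the lower of the two numbers measured so far: in a functional assay on OVCAR-8 cells (Homo sapiens) for antiproliferative activity (on this read-out lower numbers stand for stronger inhibition and higher numbers for weaker inhibition), compound 1 gives 1000 nM, whereas compound 2 `CC(=O)OCC[C@@H]1C[C@@H](c2ccc(F)c(F)c2)[C@H](NC(=O)c2cc(-c3c(Cl)cnn3C)c(Cl)o2)CN1` gives 4960 nM in this assay, a weaker result that lies beyond the scatter. Compound 3 `COCC[C@@H]1C[C@@H](c2ccc(Cl)c(Cl)c2)[C@H](NC(=O)c2cc(-c3c(Cl)cnn3C)c(Cl)o2)CN1` differs from compound 1 in a single place: methoxymethyl in place of carbamoyl on a saturated chain carbon bound to a saturated ring carbon. Within the data shown here, no measured pair shows this change, so nothing fixes its size. Compound 3 is therefore expected to give about 1600 nM in this assay, between 450 nM and 6000 nM. The expected step of a 1.6-fold higher number from compound 1 to compound 3 (0.20 log units; within the scatter) is estimated to be a modest weakening, possibly still within the scatter.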

Compound 3, half-maximal inhibitory concentration: 1060 nM
For compound 3 the middle estimate is 1.5-fold (0.18 log units) above the measured one; the measured number falls inside the stated range.
By their numbers in this assay, from the lowest: compounds 1 and 3 (each within the scatter of the next); then compound 2.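

In this assay the step of a 1.1-fold higher number from compound 1 to compound 3 (0.03 log units; within the scatter) shows that methoxymethyl can stand in place of carbamoyl on a saturated chain carbon bound to a saturated ring carbon with no change beyond the scatter. The hydrogen-bond donor counted on carbamoyl is absent from methoxymethyl, and the read-out still shows no separation between the two compounds. No measured evidence bears on why this is so. The compounds shown leave open how an amine, a carboxylic acid or a longer chain would read at this place.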